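The source may hold more compounds than are shown below. What is called first, only, known or untested is meant among the compounds shown, and "the series" means these compounds.

Of the compounds shown here, three on the same core have been measured in an in vitro ADME assay on microsomes from liver (Homo sapiens) for metabolic stability; a higher number here means faster removal of the compound, a lower number slower removal. Compound 1, `CC(C)C(=O)N(Cc1ccccc1C(F)(F)F)[C@H]1CCNC1`, gives < 7 mL.min-1.g-1, which is a limit of this assay rather than a number. Compound 2, `CC(C)S(=O)(=O)N(Cc1ccccc1-c1ccccc1)[C@H]1CCNC1`, gives 20 mL.min-1.g-1 in this assay. Compound 3, `CC(=O)N(Cc1ccccc1-c1ccccc1)[C@H]1CCNC1`, gives < 7 mL.min-1.g-1, again a limit of this assay and not a number, so that compound 3 sits at the limit of < 7 mL.min-1.g-1 in this assay, at which 2 of the 3 values shown sit. Among the compounds with values here, the one step among the measured compounds that touches this position is an at least 2.8-fold lower number from compound 2 to compound 3 (0.45 log units; beyond the scatter).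

Compound 4, `CCS(=O)(=O)N(Cc1ccccc1-c1ccccc1)[C@H]1CCNC1`, differs from compound 3 as ethylsulfonyl in place of acetyl on an amine nitrogen. This change runs the measured step in the reverse direction, with ethylsulfonyl rather than isopropylsulfonyl entering, so compound 4 is expected to move back toward the value of compound 2 with a step of an at least 2.0-fold higher number from compound 3 to compound 4 (0.30 log units; that floor lies within the scatter) in this assay. Compound 4 is therefore estimated at 14 mL.min-1.g-1, with a range from 7 mL.min-1.g-1 to 30 mL.min-1.g-1.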

Compound 4, intrinsic clearance in microsomes: < 7 mL.min-1.g-1
Compound 4: no number, only a limit; the forecaster's own chance of this, stated with the estimate: 25%; middle value at least 2.0-fold (0.30 log units) from the limit.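

In this assay compound 4 gives < 7 mL.min-1.g-1, which is a limit of the assay and not a number, and it joins the other compounds held there: the limit of < 7 mL.min-1.g-1 in this assay, at which 3 of the 4 values shown sit. This shows that a sulfonyl group on this amine nitrogen does not by itself bring a readable clearance, since hydrogen in place of methyl on the saturated chain carbon bound to the sulfonyl sulfur gives an at least 2.8-fold lower number from compound 2 to compound 4 (0.45 log units; beyond the scatter). The step from compound 3 to compound 4 cannot be read, as both values are limits, so acetyl and ethylsulfonyl cannot be ordered here.

Going by these compounds, how far under the limit compound 3 and compound 4 lie remains open. Also open, on these data alone, is whether clearance would return with a longer chain on the sulfonyl, such as butylsulfonyl, or with a phenylsulfonyl group.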